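Swapping the methoxymethyl of compound 1 for a dimethylcarbamoyl

The source may report more compounds than this note shows. Statements on the series, on what has been measured and on what is new or still open speak of the compounds shown alone.

Compound 1 `COC/C1=C/C[C@](C)(CCC=C(C)C)/C=C/[C@@H](OC(=O)C=C(C)C)[C@](C)(O)/C=C/C1=O` is the reference point of this small set. In a functional assay on MCF7 cells (Homo sapiens) for antiproliferative activity, read by MTT assay, with a stated time of 48 h (on this read-out lower numbers stand for stronger inhibition and higher numbers for weaker inhibition), compound 1 gives 4130 nM, the lowest of the three numbers recorded. Its nearest neighbour is compound 2 `CC(C)=CCC[C@]1(C)/C=C/[C@@H](OC(=O)C=C(C)C)[C@](C)(O)/C=C/C(=O)/C(C=O)=C\C1`, which gives 12600 nM; the change is a 3.1-fold higher number from compound 1 to compound 2 (0.48 log units; beyond the scatter). Furthest away is compound 3 `CC(C)=CCC[C@]1(C)/C=C/[C@@H](OC(=O)C=C(C)C)[C@](C)(O)/C=C/C(=O)/C(C[Si](c2ccccc2)(c2ccccc2)C(C)(C)C)=C\C1`, which gives 15800 nM.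

The next compound, compound 4 `CC(C)=CCC[C@]1(C)/C=C/[C@@H](OC(=O)C=C(C)C)[C@](C)(O)/C=C/C(=O)/C(C(=O)N(C)C)=C\C1`, differs from compound 1 in a single place: dimethylcarbamoyl in place of methoxymethyl on a double-bonded ring carbon. For the measured compounds named here, the only measured step that bears on this change is the one from compound 1 to compound 2, where a different carbonyl-bearing group also replaced the methoxymethyl and the number rose by a 3.1-fold higher number from compound 1 to compound 2 (0.48 log units; beyond the scatter). Nothing here shows a replacement of the methoxymethyl that lowered the number, so a rise of similar size is expected for compound 4 in this assay, namely a 2.4-fold higher number from compound 1 to compound 4 (0.38 log units; beyond the scatter). The estimate for compound 4 is therefore 10000 nM, with a likely range from 3500 nM to 28000 nM.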

Compound 4, half-maximal inhibitory concentration: 3670 nM
Compound 4: the middle estimate sits 2.7-fold (0.44 log units) above what was measured; the range from low to high includes it.
By their numbers in this assay, from the lowest: compounds 4 and 1 (each within the scatter of the next); then compounds 2 and 3 (each within the scatter of the next).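

In this assay, dimethylcarbamoyl on this double-bonded ring carbon cannot be told apart from methoxymethyl (a 1.1-fold lower number from compound 1 to compound 4 (0.05 log units; within the scatter)), so a carbonyl attached at this place does not in itself go with a higher number. The change on the carbonyl carbon itself, dimethylamino in place of hydrogen, does register (a 3.4-fold lower number from compound 2 to compound 4 (0.54 log units; beyond the scatter)), which shows that the number here follows what that carbonyl carbon bears, and that among these three groups the formyl of compound 2 stands apart. Nothing measured on these compounds accounts for that difference.

On these data alone, it remains open whether a carboxylic acid, a methyl ester or an amide with a single methyl on nitrogen would stay level with compound 1 or move towards compound 2. Equally open, as far as these compounds go, is whether a longer chain on the amide nitrogen, or a morpholine amide, would keep the number of compound 4.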